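Replacing the Sulfonyl Group on the Urea Nitrogen

The compounds below may be only part of what the source reports. "The series", "measured", "known", "first", "only" and "open" are said of these compounds alone.

In an assay on HEK293 cells for displacement of a labelled ligand from melanin-concentrating hormone receptor 1 (Homo sapiens) (a higher number here means a weaker inhibitor, a lower number a stronger inhibitor), three compounds have been measured:
compound 1, `O=C(NC1CCN(Cc2ccn(-c3ccc(C(F)(F)F)cc3)c2)CC1)NS(=O)(=O)c1ccc(F)cc1`, 617 nM
compound 2, `O=C(NCC1(O)CCCCC1)NC1CCN(Cc2ccn(-c3ccc(C(F)(F)F)cc3)c2)CC1`, 44 nM
compound 3, `O=C(O)CC(NC(=O)NC1CCN(Cc2ccn(-c3ccc(C(F)(F)F)cc3)c2)CC1)c1ccccc1`, 412 nM

Compound 1 has the highest of these three numbers. One step away from it stays within the scatter: a 1.5-fold lower number from compound 1 to compound 3 (0.18 log units; within the scatter). The other is large: a 14-fold lower number from compound 1 to compound 2 (1.15 log units; beyond the scatter).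

Compound 4, `O=C(NC1CCN(Cc2ccn(-c3ccc(C(F)(F)F)cc3)c2)CC1)N1CCCCC1CCO`, differs from compound 1 in one place: 2-(2-hydroxyethyl)piperidin-1-yl in place of ((4-fluorophenyl)sulfonyl)amino on a carbonyl carbon. Among the measured compounds shown here, the incoming group contains a hydroxyl, like the incoming group of the large step of a 14-fold lower number from compound 1 to compound 2 (1.15 log units; beyond the scatter), the only measured step that bears on this change; no measured step tests the loss of the hydrogen-bond donor at the carbonyl. Compound 4 is therefore expected to give a lower number, estimated as a 5.6-fold lower number from compound 1 to compound 4 (0.75 log units; beyond the scatter). The estimate for compound 4 is 110 nM, with a range from 30 nM to 400 nM.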

Compound 4, half-maximal inhibitory concentration: 39 nM
The estimate for compound 4 lay 2.8-fold (0.45 log units) above the measured number, within the range that was stated.
By their numbers in this assay, from the lowest: compounds 4 and 2 (each within the scatter of the next); then compounds 3 and 1 (each within the scatter of the next).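

The hydrogen on the nitrogen attached to the carbonyl carbon is not needed in this assay: 2-(2-hydroxyethyl)piperidin-1-yl has none there, yet the number matches that of the group that keeps it (a 1.1-fold lower number from compound 2 to compound 4 (0.05 log units; within the scatter)). Both hydroxyl-bearing groups give far lower numbers than the sulfonyl group (a 16-fold lower number from compound 1 to compound 4 (1.20 log units; beyond the scatter)) and the carboxylic acid group (an 11-fold lower number from compound 3 to compound 4 (1.02 log units; beyond the scatter)). No measurement shown explains these steps.

From the compounds shown here alone, whether the hydroxyl itself matters remains open. A plain piperidin-1-yl, or an amine in place of the hydroxyl, would test that.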